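What compound 4 may do after compound 3

The source may report more compounds than this note shows. Statements on the series, on what has been measured and on what is new or still open speak of the compounds shown alone.

Compound 1 `CCOc1ncc(-c2nc(C(F)(F)F)sc2N2CCN(C(=O)Cn3cnc4ccccc43)[C@H](C)C2)cn1`: 662 mL.min-1.g-1
Compound 2 `CCOc1ncc(-c2nc(C(F)(F)F)sc2N2CCN(C(=O)Cn3ncc4cccnc43)[C@H](C)C2)cn1`: 41 mL.min-1.g-1
Compound 3 `CCOc1ncc(-c2nc(C(F)(F)F)sc2N2CCN(C(=O)Cn3nc(C)nc3C)[C@H](C)C2)cn1`: < 10 mL.min-1.g-1 (a limit, not a number)

In a toxicity assay on microsomes from liver (Homo sapiens) for metabolic stability, read by LC-MS, using NADPH, tested at 1 uM (a higher number here means faster removal of the compound, a lower number slower removal), compound 3 stands at < 10 mL.min-1.g-1 as a limit of the assay, not a number. Compound 4 `CCOc1ncc(-c2nc(C(F)(F)F)sc2N2CCN(C(=O)Cn3ccc(C(F)(F)F)n3)[C@H](C)C2)cn1` differs from it at one place (3-(trifluoromethyl)-1H-pyrazol-1-yl in place of 3,5-dimethyl-1H-1,2,4-triazol-1-yl on a saturated chain carbon bound to a carbonyl carbon) on a saturated chain carbon bound to a carbonyl carbon: 3-(trifluoromethyl)-1H-pyrazol-1-yl in place of 3,5-dimethyl-1H-1,2,4-triazol-1-yl. Three measured steps at this same place bear on the change, all falling and all beyond the scatter: (a 16-fold lower number from compound 1 to compound 2 (1.21 log units; beyond the scatter)), (an at least 66-fold lower number from compound 1 to compound 3 (1.82 log units; beyond the scatter)) and (an at least 4.1-fold lower number from compound 2 to compound 3 (0.61 log units; beyond the scatter)). They lead away from the two-ring groups of compound 1 and compound 2. With a single five-membered aromatic ring kept, only a modest rise is expected (an at least 2.5-fold higher number from compound 3 to compound 4 (0.39 log units; beyond the scatter)). In this assay compound 4 is estimated at 25 mL.min-1.g-1 with a likely range from 10 mL.min-1.g-1 to 80 mL.min-1.g-1 (an estimate, not a measurement).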

Compound 4, intrinsic clearance in microsomes: 20 mL.min-1.g-1
For compound 4 the middle estimate is 1.3-fold (0.10 log units) above the measured one; the measured number falls inside the stated range.
By their numbers in this assay, from the lowest: compound 4; then compound 2; then compound 1. At a limit, below all of these: compound 3.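

In this assay, a single five-membered aromatic ring that carries trifluoromethyl also gives a low number, so this is not confined to 3,5-dimethyl-1H-1,2,4-triazol-1-yl: against the two-ring groups, the change gives a 33-fold lower number from compound 1 to compound 4 (1.52 log units; beyond the scatter) and a 2.1-fold lower number from compound 2 to compound 4 (0.31 log units; beyond the scatter). Between the two single-ring groups, the step reads an at least 2.0-fold higher number from compound 3 to compound 4 (0.30 log units; that floor lies within the scatter). Compound 3 stands at a limit, not a number, so the true gap stays unknown: the limit of < 10 mL.min-1.g-1 in this assay, at which 1 of the 4 values shown sits.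

Going by these compounds, what a nitrile or an amine in place of the trifluoromethyl would do in this assay stays open, as does a longer chain bound to the carbonyl carbon.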